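The source may report more compounds than this note shows. Statements on the series, on what has been measured and on what is new or still open speak of the compounds shown alone.

Working notes on the series.

Compound 1 `FC(F)(F)c1ccc(-c2ccc3c(NCCCNCc4ccco4)ccnc3c2)cc1` gives 3470 nM in an ADME assay on HepG2 cells (Homo sapiens) for cytotoxicity, read by luminescence, CellTiter-Glo and ATP content, with a stated time of 72 h; a lower number here means that less compound is needed, a higher number that more compound is needed for the effect. Compound 2 `CC(C)(C)c1ccc(-c2ccc3c(NCCCNCc4ccco4)ccnc3c2)cc1` gives 3150 nM in this assay. The difference between them is trifluoromethyl in place of tert-butyl on an aromatic carbon, and the step it made is a 1.1-fold higher number from compound 2 to compound 1 (0.04 log units; within the scatter). Among the compounds with values here, compound 3 `COc1ccc(F)cc1CNCCCNc1ccnc2cc(-c3ccc(C(C)(C)C)cc3)ccc12` gives 620 nM in this assay, the lowest number of the three measured so far. Its difference from compound 2 is 5-fluoro-2-methoxyphenyl in place of furan-2-yl on a saturated chain carbon bound to an amine nitrogen, and the step there is a 5.1-fold lower number from compound 2 to compound 3 (0.71 log units; beyond the scatter).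

Compound 4 `COc1ccc(F)cc1CNCCCNc1ccnc2cc(-c3ccc(C(F)(F)F)cc3)ccc12` is not yet measured. It differs from compound 3 by trifluoromethyl in place of tert-butyl on an aromatic carbon, which is the same change already seen once in the series, where it made a 1.1-fold higher number from compound 2 to compound 1 (0.04 log units; within the scatter). The place of the change reads the same in both cases, so this is the same change, not merely the same kind. The two cores differ by 5-fluoro-2-methoxyphenyl in place of furan-2-yl on a saturated chain carbon bound to an amine nitrogen.

For compound 4 a step of a 1.1-fold higher number from compound 3 to compound 4 (0.04 log units; within the scatter) in this assay is expected, within the scatter, resting on the earlier 1.1-fold higher number from compound 2 to compound 1 (0.04 log units; within the scatter). The expected value for compound 4 is 680 nM, estimated to lie between 320 nM and 1500 nM.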

Compound 4, half-maximal effective concentration: 5190 nM
Compound 4: the middle estimate sits 7.6-fold (0.88 log units) below what was measured; measured number above the stated range.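

The change from tert-butyl to trifluoromethyl does not carry over as a fixed step between the two cores in this assay, where an 8.4-fold higher number from compound 3 to compound 4 (0.92 log units; beyond the scatter) stands against the earlier step: the same change on two cores in this assay, a 1.1-fold higher number (0.04 log units; within the scatter) from compound 2 to compound 1 and an 8.4-fold higher number (0.92 log units; beyond the scatter) from compound 3 to compound 4, 7.6-fold (0.88 log units) apart, beyond the scatter of two such steps.

The other change depends on the core in the same way, with a 1.5-fold higher number from compound 1 to compound 4 (0.17 log units; within the scatter) set against the step on the tert-butyl side: the same change on two cores in this assay, a 5.1-fold lower number (0.71 log units; beyond the scatter) from compound 2 to compound 3 and a 1.5-fold higher number (0.17 log units; within the scatter) from compound 1 to compound 4, 7.6-fold (0.88 log units) apart, beyond the scatter of two such steps.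

Among these four compounds the lower number appears only in compound 3, which combines tert-butyl with 5-fluoro-2-methoxyphenyl, but this does not show why the two changes fail to add up or how either would behave on a further core.

As far as these compounds go, it remains open whether the lower number of compound 3 is specific to tert-butyl or would persist with a group such as isopropyl in its place. From the compounds shown here alone, it is also open whether it depends on the fluorine or on the methoxy of the 5-fluoro-2-methoxyphenyl group, and whether it would survive a longer chain between the two amine nitrogens.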